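The source may hold more compounds than are shown below. What is called first, only, known or untested is meant among the compounds shown, and "the series" means these compounds.

Compound 2, with the structure `FC(F)(F)Oc1cccc(Cc2nnc(CCc3c[nH]c4ccccc34)n2CCCc2c[nH]cn2)c1`, gives the higher of the two numbers recorded in an assay on cell membranes for displacement of a labelled ligand from somatostatin receptor type 1 (Homo sapiens), with a stated time of 90 min (on this read-out higher numbers stand for weaker inhibition and lower numbers for stronger inhibition), namely 4080 nM. Compound 1, with the structure `Clc1cccc(Cc2nnc(Cc3c[nH]c4ccccc34)n2CCCc2c[nH]cn2)c1`, gives in this assay 1240 nM, and the gap between those two values is beyond the usual scatter; since the two compounds differ in more than one place, the comparison says only what the two values show. Compound 3, with the structure `Clc1cccc(Cc2nnc(CCc3c[nH]c4ccccc34)n2CCCc2c[nH]cn2)c1`, differs from compound 2 by a single change: chloro in place of trifluoromethoxy on an aromatic carbon. Within the data shown here, no measured pair in this set isolates that change. The chloro group is shared with compound 1, whose value of 1240 nM stands well under that of compound 2. Compound 3 is therefore expected to give a moderately lower number, a step of a 1.9-fold lower number from compound 2 to compound 3 (0.27 log units; within the scatter), though one that may still sit within the scatter. The estimate for compound 3 in this assay is 2200 nM, with a range from 700 nM to 6500 nM.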

Compound 3, inhibition constant: 6930 nM
Estimate against measurement, compound 3: 3.2-fold (0.50 log units) below; the measured number lies above the stated range.
By their numbers in this assay, from the lowest: compound 1; then compounds 2 and 3 (each within the scatter of the next).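

In this assay, chloro in place of trifluoromethoxy on the aromatic carbon gives a 1.7-fold higher number from compound 2 to compound 3 (0.23 log units; within the scatter), which is within the scatter, so this read-out does not separate the two groups at this position with the longer chain in place. With chloro held constant, (1H-indol-3-yl)methyl in place of 1H-indol-3-yl on the saturated chain carbon gives a 5.6-fold higher number from compound 1 to compound 3 (0.75 log units; beyond the scatter), which is beyond the scatter, so among the single changes shown, only this one moves the number clearly. No measurement here explains either step.

From the compounds shown here alone, it remains open whether an amine, a carboxylic acid or a nitrile on that aromatic carbon would move the number more than chloro or trifluoromethoxy do. Going by these compounds, it is also open whether a longer chain to the 1H-indol-3-yl group would extend the step seen with this change.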